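The source may hold more compounds than are shown below. What is called first, only, known or untested is meant among the compounds shown, and "the series" means these compounds.

Series notes on the shared core. Compound 1, `O=S(=O)(/C=C/c1ccc(Br)cc1)Cc1ccc(Nc2ncnc3ccccc23)cc1`, is the starting point. In a functional assay on HT-29 cells (Homo sapiens) (a higher number here means a weaker inhibitor of growth, a lower number a stronger inhibitor of growth), compound 1 gives only a limit, > 100000 nM, and no number. Compound 2, `CC(C)(C)c1cc(/C=C/S(=O)(=O)Cc2ccc(Nc3ncnc4ccccc34)cc2)cc(C(C)(C)C)c1O`, carries the same core, and in this assay compound 2 gives 17000 nM. For the measured compounds named here, compound 1 and compound 2 differ in more than one place, so no single step connects them; the pair shows only that one value is a number and the other is a limit, as recorded for (the limit of > 100000 nM in this assay, at which 1 of the 2 values shown sits).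

Compound 3, `O=S(=O)(/C=C/c1ccc(C(F)(F)F)cc1F)Cc1ccc(Nc2ncnc3ccccc23)cc1`, is not yet measured. It differs from compound 1 by one change: 2-fluoro-4-(trifluoromethyl)phenyl in place of 4-bromophenyl on a double-bonded chain carbon bound to a double-bonded chain carbon. Going by the values given here, no measured step in this assay covers a change of this kind, so the size and direction of the step are open. Compound 1 sits at the limit of this assay, and the change keeps the count of hydrogen-bond donors and acceptors the same, which gives no footing for a large move. The step from compound 1 to compound 3 is expected to be an at least 1.2-fold lower number from compound 1 to compound 3 (0.09 log units; that floor lies within the scatter), or none beyond the scatter. Compound 3 is estimated in this assay at 80000 nM, with a range from 25000 nM to 300000 nM.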

Compound 3, concentration for 50% growth inhibition: 100000 nM
Compound 3: the middle estimate sits 1.3-fold (0.10 log units) below what was measured; measured number inside the range.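

In this assay compound 1 gives > 100000 nM, which is a limit and not a number. For the compounds shown here, compound 3 gives a number, 100000 nM, so 2-fluoro-4-(trifluoromethyl)phenyl in place of 4-bromophenyl on a double-bonded chain carbon bound to a double-bonded chain carbon provides the first value at this position that is not a limit. The step is a number no higher from compound 1 to compound 3 (the limit leaves the size open). This change therefore gives no measured size for any change at this position, and the series still contains a value at the limit: the limit of > 100000 nM in this assay, at which 1 of the 3 values shown sits.

What the compounds shown leave open is whether any group at this position gives a step of readable size, and whether the number of compound 2, 17000 nM, can be tied to a single change, as it differs from compound 1 in more than one place. Also open, as far as these compounds go, is how a group such as an amine or a carboxylic acid on the phenyl ring would read in this assay.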